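Cyclohexyl for phenyl on the ether of compound 1

The source may report more compounds than this note shows. Statements on the series, on what has been measured and on what is new or still open speak of the compounds shown alone.

Compound 1 `O=C1CSc2cc(OCc3ccccc3)ccc2N1`: 8060 nM
Compound 2 `O=C1CSc2cc(OCc3ccc(Cl)cc3)ccc2N1`: 24400 nM

In an assay on isolated protein for inhibition of Amine oxidase [flavin-containing] A (Homo sapiens), read by fluorescence and spectrophotometry, with a stated time of 20 min (a lower number here means a stronger inhibitor, a higher number a weaker inhibitor), compound 1 gives the lowest of the two numbers, and its nearest neighbour is compound 2, reached by a 3.0-fold higher number from compound 1 to compound 2 (0.48 log units; beyond the scatter). Compound 3 `O=C1CSc2cc(OCC3CCCCC3)ccc2N1` carries cyclohexyl in place of phenyl on a saturated chain carbon bound to an oxygen on an aromatic ring. Among the compounds with values here, no measured pair traces this exchange; the only step known, from compound 1 to compound 2, alters the same ring and is modest. A step of similar size, in the same direction or none beyond the scatter, is therefore expected for compound 3 in this assay, namely a 1.5-fold higher number from compound 1 to compound 3 (0.17 log units; within the scatter). Compound 3 is thus estimated at 12000 nM, between 4000 nM and 40000 nM.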

Compound 3, half-maximal inhibitory concentration: 1170 nM
Compound 3: the middle estimate sits 10-fold (1.01 log units) above what was measured, and the stated range ends above it.
By their numbers in this assay, from the lowest: compound 3; then compound 1; then compound 2.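

In this assay, replacing the phenyl on the saturated chain carbon bound to an oxygen on an aromatic ring with cyclohexyl gives a 6.9-fold lower number from compound 1 to compound 3 (0.84 log units; beyond the scatter), so an aromatic ring is not needed there for inhibition. Within the data shown here, the change also moves the number the opposite way from the only earlier step, a 3.0-fold higher number from compound 1 to compound 2 (0.48 log units; beyond the scatter). Nothing available explains this shift. On these data alone, whether a cyclopentyl ring or a longer chain would lower the number further remains open. So does whether chloro or an amine on the cyclohexyl ring would raise it.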